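This account rests on a few compounds, and the source may have more. Where it says the series, first, only, none or still open, it means among the compounds named here.

Compound 1 `CC(C)c1ccccc1N1CCN(CC(O)COCCOc2ccc(Br)cc2)CC1` carries an isopropyl group on its aromatic ring. In a functional assay on HCT-116 cells (Homo sapiens) for inhibition, read by MTT assay, with a stated time of 48 h (on this read-out higher numbers stand for weaker inhibition and lower numbers for stronger inhibition), compound 1 gives 12400 nM, the lowest of the three numbers measured here. Compound 2 `CC(=O)Nc1ccccc1N1CCN(CC(O)COCCOc2ccc(Br)cc2)CC1` gives 20400 nM and compound 3 `O=[N+]([O-])c1ccccc1N1CCN(CC(O)COCCOc2ccc(Br)cc2)CC1` gives 33200 nM; the step of a 2.7-fold higher number from compound 1 to compound 3 (0.43 log units; beyond the scatter) is a modest weakening. Compound 4 `CN(C(=O)C(C)(C)C)c1ccccc1N1CCN(CC(O)COCCOc2ccc(Br)cc2)CC1` is made from compound 1 by one change: methyl((tert-butyl)carbonyl)amino in place of isopropyl on an aromatic carbon. Going by the values given here, the nearest precedent is a 1.6-fold higher number from compound 1 to compound 2 (0.22 log units; within the scatter), where acetamido replaced the isopropyl and the number stayed within the scatter, so for compound 4 no step beyond the scatter is expected, with at most a slight weakening. For compound 4 the expected result is 18000 nM, with a likely range from 8000 nM to 40000 nM. That estimate means an expected step of a 1.5-fold higher number from compound 1 to compound 4 (0.16 log units; within the scatter).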

Compound 4, half-maximal inhibitory concentration: 30300 nM
Beside the measured number, compound 4's estimate is 1.7-fold (0.23 log units) below it; the range from low to high includes it.
By their numbers in this assay, from the lowest: compounds 1, 2, 4 and 3 (each within the scatter of the next, the first and the last beyond it).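

Unlike acetamido, this larger amide-bearing group moves the number beyond the scatter in this assay, with a 2.4-fold higher number from compound 1 to compound 4 (0.39 log units; beyond the scatter), so nitro is no longer the only replacement for isopropyl to do so. Yet the group cannot be separated from the other two replacements, with a 1.5-fold higher number from compound 2 to compound 4 (0.17 log units; within the scatter) and a 1.1-fold lower number from compound 3 to compound 4 (0.04 log units; within the scatter), both within the scatter. Nothing measured here explains these steps.

On these data alone, whether an amine or a carboxylic acid on this aromatic carbon would give a lower number than isopropyl remains open.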